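A few compounds are considered here, and "the series" means these few. Any claim that something is new, unique, unknown or untested is made for them only; others in the source may bear on it.

Compound 1 `CC1=C(/C=C/C(=O)/C=C/c2cccc(C(F)(F)F)c2)C(C)(C)CCC1` gives 2800 nM in a functional assay on LNCaP cells (Homo sapiens) for cytotoxicity, read by MTT assay, with a stated time of 72 h; a lower number here means a stronger inhibitor, a higher number a weaker inhibitor.
Compound 2 `CC1=C(/C=C/C(=O)/C=C/c2cc(C(F)(F)F)cc(C(F)(F)F)c2)C(C)(C)CCC1` gives 8700 nM.
Compound 3 `CC1=C(/C=C/C(=O)/C=C/c2ccccc2F)C(C)(C)CCC1O` gives 2900 nM.

Compounds 1 and 2 differ in one place: trifluoromethyl in place of hydrogen on an aromatic carbon. That change made a 3.1-fold higher number from compound 1 to compound 2 (0.49 log units; beyond the scatter). The same kind of change leads from compound 3 to the unmeasured compound 4 `CC1=C(/C=C/C(=O)/C=C/c2cccc(C(F)(F)F)c2F)C(C)(C)CCC1O`: trifluoromethyl in place of hydrogen on an aromatic carbon. The surroundings are not the same word for word: in compound 2 the entering group is meta to a trifluoromethyl group, in compound 4 it is ortho to a fluoro group, so this is the same kind of change, not the same. How the core of compound 3 differs from that of compound 1 is not broken down here. Since compound 1 at 2800 nM and compound 3 at 2900 nM lie within the scatter of each other, the earlier step serves as the guide. Compound 4 is expected to show a 2.2-fold higher number from compound 3 to compound 4 (0.35 log units; beyond the scatter) beside that earlier step. Compound 4 is therefore estimated at 6500 nM, between 3000 nM and 14000 nM.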

Compound 4, half-maximal inhibitory concentration: 1100 nM
Compound 4: the middle estimate sits 5.9-fold (0.77 log units) above what was measured, and the stated range ends above it.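

The same change now gives a 2.6-fold lower number from compound 3 to compound 4 (0.42 log units; beyond the scatter) in this assay, so its effect did not carry over from one core to the other, even in direction. The two steps differ by more than their scatter: the same change on two cores in this assay, a 3.1-fold higher number (0.49 log units; beyond the scatter) from compound 1 to compound 2 and a 2.6-fold lower number (0.42 log units; beyond the scatter) from compound 3 to compound 4, 8.2-fold (0.91 log units) apart, beyond the scatter of two such steps
This does not show what sets the two steps apart, as the two pairs differ both in their cores and in the surroundings of the entering group, and two pairs alone cannot separate these differences.

As far as these compounds go, it remains open whether trifluoromethyl ortho to a fluoro group would also lower the number on the core of compound 1. From the compounds shown here alone, how a chloro or a methoxy group in the same place would behave on either core also remains open.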